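Swapping the amine aryl on a shared core

The compounds below may be only part of what the source reports. "The series", "measured", "known", "first", "only" and "open" are said of these compounds alone.

For the measured compounds named here, compound 3 `Cc1ccnc(NC(c2ccccc2)c2ccc3cccnc3c2O)c1` is one of three compounds measured in an assay for inhibition of protein disulfide-isomerase (Homo sapiens), with a stated time of 1 h; on this read-out higher numbers stand for weaker inhibition and lower numbers for stronger inhibition. For compound 3 the result is a limit of the assay, < 200 nM. Compound 1 `COc1ccc(C(Nc2cc(C)ccn2)c2ccc3cccnc3c2O)cc1O` gives 150 nM in this assay. For compound 2 `Cc1ccnc(NC(c2ccc3cccnc3c2O)c2c(F)cccc2Cl)c1` the result is also a limit, > 40000 nM. The two readable steps, an at least 260-fold higher number from compound 1 to compound 2 (2.42 log units; beyond the scatter) and an at least 200-fold lower number from compound 2 to compound 3 (2.30 log units; beyond the scatter), both change the aryl on the saturated chain carbon, and the step that the limit leaves unreadable from compound 1 to compound 3. Compound 4 `COc1ccccc1NC(c1ccccc1)c1ccc2cccnc2c1O` differs from compound 3 at the amine nitrogen, where (2-methoxyphenyl in place of 4-methylpyridin-2-yl on an amine nitrogen). Going by the values given here, no measured step touches this position, so the expectation for compound 4 in this assay rests on compound 3 alone and is a step of no clear size, an at least 1.2-fold higher number from compound 3 to compound 4 (0.09 log units; that floor lies within the scatter). Compound 4 is therefore estimated at 250 nM, between 50 nM and 1500 nM.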

Compound 4, half-maximal inhibitory concentration: 390 nM
The estimate for compound 4 lay 1.6-fold (0.19 log units) below the measured number; the range from low to high includes it.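

For the compounds shown here, the change at the amine nitrogen is the first one read at this position: in this assay it gives an at least 1.9-fold higher number from compound 3 to compound 4 (0.29 log units; that floor lies within the scatter). With 2-methoxyphenyl, whose aromatic ring is of carbon only, compound 4 still gives 390 nM, so a ring hetero atom at this position is not needed for a value of this order. How far the step truly reaches stays unreadable, since compound 3 carries only a limit: the limit of < 200 nM in this assay, at which 1 of the 4 values shown sits.

The compounds shown leave open whether the methoxy group or the change of ring matters more, since both change together. They also leave open how a plain phenyl or a saturated cyclohexyl group on this nitrogen would read.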